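A methyl for a chloro on the aryl amine

The source may report more compounds than this note shows. Statements on the series, on what has been measured and on what is new or still open speak of the compounds shown alone.

Compound 1 `COc1cc(Nc2nc(Nc3ccc(Cl)cc3)nnc2Cl)cc(OC)c1OC` gives 9610 nM in a functional assay on PC-3 cells (Homo sapiens) for inhibition, read by MTT assay, with a stated time of 48 h; on this read-out lower numbers stand for stronger inhibition and higher numbers for weaker inhibition
Compound 2 `COc1cccc(Nc2nnc(Cl)c(Nc3cc(OC)c(OC)c(OC)c3)n2)c1` gives 11300 nM in this assay

Among the measured compounds shown here, only these two numbers are known so far in this assay and they lie within the scatter of each other, so compound 1 has no clear rank against its one neighbour. Compound 3 `COc1cc(Nc2nc(Nc3ccc(C)cc3)nnc2Cl)cc(OC)c1OC` has not yet been measured. It keeps the core of compound 1 and alters one group: the difference is methyl in place of chloro on an aromatic carbon and amounts to methyl in place of chloro on an aromatic carbon, para to a large group, turning 4-chlorophenyl into 4-methylphenyl.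

For the measured compounds named here, no measured step makes this exact exchange. The nearest evidence is 3-methoxyphenyl in place of 4-chlorophenyl on a nitrogen, which is a 1.2-fold higher number from compound 1 to compound 2 (0.07 log units; within the scatter) and stays within the scatter. That is a single step, so it is thin support, but no change beyond the scatter is expected in this assay here. The estimated step is a 1.0-fold higher number from compound 1 to compound 3 (0.02 log units; within the scatter) and it carries no clear direction. For compound 3 the estimate is 10000 nM with an expected range of 4500 nM to 22000 nM in this measurement.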

Compound 3, half-maximal inhibitory concentration: 14300 nM
Compound 3: middle estimate off by 1.4-fold (0.16 log units), on the low side; measured number inside the range.
By their numbers in this assay, from the lowest: compounds 1, 2 and 3 (each within the scatter of the next).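

In this assay, the exchange of chloro for methyl on the aromatic carbon, para to a large group, can now be read directly: it gives a 1.5-fold higher number from compound 1 to compound 3 (0.17 log units; within the scatter). Compared with the other aryl group on this nitrogen, 4-methylphenyl in place of 3-methoxyphenyl gives a 1.3-fold higher number from compound 2 to compound 3 (0.10 log units; within the scatter), so all three pairs among 4-chlorophenyl, 3-methoxyphenyl and 4-methylphenyl now lie within the scatter, and none of these groups separates from the others. No independent measurement is available to account for this flat result.

The compounds shown leave open whether this aryl ring would respond to a group of another kind, such as an amine, a carboxylic acid or a longer chain in place of the methyl of compound 3. They also leave open whether the remaining chloro on the shared core, or the trimethoxy-substituted aryl group on the other nitrogen, has any greater bearing on these numbers.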